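A few compounds are considered here, and "the series" means these few. Any claim that something is new, unique, unknown or untested is made for them only; others in the source may bear on it.

Of the compounds shown here, three sharing one core have been measured in a functional assay on HeLa cells (Homo sapiens) for inhibition; a lower number here means a stronger inhibitor, a higher number a weaker inhibitor. Compound 1 `Oc1cccc(-c2cc(-c3cccc(F)c3)cc(-c3ccccc3O)n2)c1` carries a fluoro group on its middle ring; in this assay compound 1 gives > 50000 nM, which is a limit of the assay and not a number. Compound 2 `Oc1cccc(-c2cc(-c3cccc(C(F)(F)F)c3)cc(-c3ccccc3O)n2)c1` carries trifluoromethyl in that spot, and in this assay compound 2 gives 19500 nM. That exchange produced an at least 2.5-fold lower number from compound 1 to compound 2 (0.40 log units; beyond the scatter). Compound 3 `Oc1ccccc1-c1cc(-c2cccc(OC(F)(F)F)c2)cc(-c2ccccc2O)n1` has two 2-hydroxyphenyl groups flanking a middle ring that bears trifluoromethoxy. In this assay compound 3 gives > 50000 nM, again a limit rather than a number. Compound 3 therefore sits at the limit of > 50000 nM in this assay, at which 2 of the 3 values shown sit, so its position relative to compound 1 cannot be ranked.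

Compound 4 `Oc1cccc(-c2cc(-c3cccc(OC(F)(F)F)c3)cc(-c3ccccc3O)n2)c1` contains the same atoms joined differently: 3-hydroxyphenyl in place of 2-hydroxyphenyl on an aromatic carbon, next to the ring nitrogen. This gives compound 4 the same hydroxyphenyl arrangement as compounds 1 and 2. For the measured compounds named here, the only measured step alters the middle ring, not a hydroxyphenyl group, so no measured step bears directly on this change. Because compound 2, the closest measured relative with this arrangement, gives 19500 nM, weak inhibition is expected for compound 4, and the step is estimated as an at least 1.4-fold lower number from compound 3 to compound 4 (0.15 log units; that floor lies within the scatter). Compound 4 is expected near 35000 nM, within 12000 nM to 100000 nM.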

Compound 4, half-maximal inhibitory concentration: 14900 nM
The estimate for compound 4 lay 2.3-fold (0.37 log units) above the measured number; the range from low to high includes it.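

In this assay, replacing 2-hydroxyphenyl with 3-hydroxyphenyl on the aromatic carbon next to the ring nitrogen, with trifluoromethoxy kept on the middle ring, gives an at least 3.3-fold lower number from compound 3 to compound 4 (0.52 log units; beyond the scatter), so this one pair shows that the position responds to which of the two hydroxyphenyl groups it carries. On the middle ring, trifluoromethoxy in place of trifluoromethyl gives a 1.3-fold lower number from compound 2 to compound 4 (0.12 log units; within the scatter), so the two groups cannot be told apart here, whereas trifluoromethoxy in place of fluoro gives an at least 3.3-fold lower number from compound 1 to compound 4 (0.52 log units; beyond the scatter), in the same direction as the earlier exchange of fluoro for trifluoromethyl. The two steps that begin at compound 1 and compound 3 are floors and not exact sizes, because each of those compounds rests on a limit of the assay and not on a number: the limit of > 50000 nM in this assay, at which 2 of the 4 values shown sit.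

On these data alone, whether the same hydroxyphenyl exchange holds with fluoro or trifluoromethyl on the middle ring stays open, as does the true distance between compound 3 and compound 4. The compounds shown also leave open what an amine, a carboxylic acid or a methoxy group in place of the hydroxyl would do on that ring next to the ring nitrogen.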